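The source may report more compounds than this note shows. Statements on the series, on what has been measured and on what is new or still open speak of the compounds shown alone.

Measured so far in a functional assay on SK-MEL-28 cells (Homo sapiens) for inhibition; on this read-out higher numbers stand for weaker inhibition and lower numbers for stronger inhibition:
Compound 1 `C(=C/c1ccco1)\c1ccc2ccccc2c1`: > 5000 nM
Compound 2 `C(=C\c1ccco1)\c1ccc2ccccc2c1`: > 5000 nM
Compound 3 `C(=C/c1ccc2ccccc2c1)\c1ccoc1`: > 5000 nM

Each of these entries is a limit of the assay, not a true number. In this assay, compound 3 gives > 5000 nM, which is also only a limit. It shares this position with the other two compounds, as the limit of > 5000 nM in this assay, at which 3 of the 3 values shown sit, shows, so no order can be drawn among the three.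

The next compound is compound 4 `C(=C\c1ccc2ccccc2c1)\c1ccoc1`, the partner of compound 3: the two compounds have the same atoms and bonds and differ only in configuration as drawn: 1 of 1 stereo elements differ; a double bond is drawn E in compound 3 and Z in compound 4.

The closest parallel is the earlier pair, given (the fact that compounds 1 and 2 differ only in the configuration as drawn). Turning the double bond from E to Z there gave a step that the two limits leave unreadable from compound 1 to compound 2. Placing furan-3-yl in place of furan-2-yl gave a step that the two limits leave unreadable from compound 1 to compound 3. Neither step has a size that can be read, so the data offer no sign that the Z form differs from the E form in this series. Among the compounds with values here, the only direct precedent for this change, a step that the two limits leave unreadable from compound 1 to compound 2, left the Z compound at the limit as well.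

No step beyond the usual scatter is expected, and the estimated change is a step that the limit leaves unreadable from compound 3 to compound 4. For compound 4 the expected value is 8000 nM, with an estimated range from 3000 nM to 20000 nM, and the assay will most likely report only a limit.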

Compound 4, half-maximal inhibitory concentration: > 5000 nM
Compound 4 gave a limit, no number; the forecaster's own chance of this, stated with the estimate: 85%; the middle value is on the limit's open side.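

In this assay compound 4 gives > 5000 nM, which is a limit of the assay and not a number. The steps to compound 4 from compound 3 and from compound 2 cannot be read, as all of these values are limits. The compounds shown leave open whether double-bond configuration or furan-3-yl in place of furan-2-yl changes inhibition at all.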